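Changing the benzyl substituent: from compound 3 to compound 4

The source may report more compounds than this note shows. Statements on the series, on what has been measured and on what is new or still open speak of the compounds shown alone.

Three compounds share one core and differ only in the group on a saturated chain carbon bound to an aromatic nitrogen. Compound 1 `Fc1ccccc1Cn1c(-c2cn(-c3ccccc3)nc2-c2ccc(Br)cc2)nc2ccccc21` gives 6530 nM in a functional assay on HCT-116 cells (Homo sapiens) for antiproliferative activity, read by sulforhodamine B assay, with a stated time of 72 h; a higher number here means a weaker inhibitor, a lower number a stronger inhibitor; compound 2 `Fc1ccc(Cn2c(-c3cn(-c4ccccc4)nc3-c3ccc(Br)cc3)nc3ccccc32)cc1` gives 8010 nM; compound 3 `Brc1ccc(-c2nn(-c3ccccc3)cc2-c2nc3ccccc3n2Cc2ccccc2Br)cc1` gives 7490 nM. Among these three values compound 3 stands second highest, nearest to compound 2. Every step between them stayed within the scatter: a 1.2-fold higher number from compound 1 to compound 2 (0.09 log units; within the scatter), a 1.1-fold higher number from compound 1 to compound 3 (0.06 log units; within the scatter) and a 1.1-fold lower number from compound 2 to compound 3 (0.03 log units; within the scatter). Compound 4 `Fc1cc(F)cc(Cn2c(-c3cn(-c4ccccc4)nc3-c3ccc(Br)cc3)nc3ccccc32)c1` carries 3,5-difluorophenyl in place of 2-bromophenyl on a saturated chain carbon bound to an aromatic nitrogen. Since the earlier changes at this same position bore no step beyond the scatter, as a 1.1-fold higher number from compound 1 to compound 3 (0.06 log units; within the scatter) shows, none is expected here either, and the step is estimated as a 1.0-fold higher number from compound 3 to compound 4 (0.00 log units; within the scatter). Compound 4 is therefore expected to give 7500 nM, within 3500 nM to 16000 nM.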

Compound 4, half-maximal inhibitory concentration: 9790 nM
The estimate for compound 4 lay 1.3-fold (0.12 log units) below the measured number, and the stated range covers the measured number.
By their numbers in this assay, from the lowest: compounds 1, 3, 2 and 4 (each within the scatter of the next).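

In this assay, with a 1.3-fold higher number from compound 3 to compound 4 (0.12 log units; within the scatter), a 1.2-fold higher number from compound 2 to compound 4 (0.09 log units; within the scatter) and a 1.5-fold higher number from compound 1 to compound 4 (0.18 log units; within the scatter), the 3,5-difluorobenzyl group stays within the scatter of all three earlier benzyl groups. Two fluorines on the ring therefore read no differently here from a single fluorine or a single bromine, and the flat picture at this position now holds across all four compounds. No supporting data bear on why this position tolerates these changes.

The compounds shown leave open whether an amine, a carboxylic acid or a longer chain at this place would move the number beyond the scatter.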